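Replacing a 4-(tert-butyl)phenyl Group in a Cytotoxic Series

A few compounds are considered here, and "the series" means these few. Any claim that something is new, unique, unknown or untested is made for them only; others in the source may bear on it.

Of the compounds shown here, three with a shared core have been measured in a functional assay on PC-3 cells (Homo sapiens) for cytotoxicity, read by MTT assay, with a stated time of 48 h; a lower number here means a stronger inhibitor, a higher number a weaker inhibitor. Compound 1 `CC1(C)CCC[C@]2(C)[C@@H](CC[C@@](C)(O)/C=C/c3cccc([N+](=O)[O-])c3)[C@](C)(O)CC[C@@H]12` gives 153 nM, and compound 2 `Cc1ccc(C)c(/C=C/[C@](C)(O)CC[C@@H]2[C@@]3(C)CCCC(C)(C)[C@@H]3CC[C@@]2(C)O)c1` gives 176 nM. The step between them, a 1.2-fold higher number from compound 1 to compound 2 (0.06 log units; within the scatter), is small. Compound 3 `CC(C)(C)c1ccc(/C=C/[C@](C)(O)CC[C@@H]2[C@@]3(C)CCCC(C)(C)[C@@H]3CC[C@@]2(C)O)cc1` stands highest of the three, and so is the weakest, at 3800 nM. The steps of a 25-fold higher number from compound 1 to compound 3 (1.40 log units; beyond the scatter) and a 22-fold higher number from compound 2 to compound 3 (1.33 log units; beyond the scatter) are both large.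

Compound 4 `Cc1cccc(C)c1/C=C/[C@](C)(O)CC[C@@H]1[C@@]2(C)CCCC(C)(C)[C@@H]2CC[C@@]1(C)O` differs from compound 3 by a single change: 2,6-dimethylphenyl in place of 4-(tert-butyl)phenyl on a double-bonded chain carbon bound to a double-bonded chain carbon. In words, 2,6-dimethylphenyl stands in place of 4-(tert-butyl)phenyl on a double-bonded chain carbon bound to a double-bonded chain carbon.

The closest guide is the step of a 22-fold higher number from compound 2 to compound 3 (1.33 log units; beyond the scatter), which links the same 4-(tert-butyl)phenyl group to another dimethylphenyl group, read here in reverse. The step of a 25-fold higher number from compound 1 to compound 3 (1.40 log units; beyond the scatter) points the same way. Going by the values given here, no measured compound carries the 2,6-dimethylphenyl group itself, so some caution is needed, and a return all the way to the level of compound 2 at 176 nM is not assumed. A large fall in the number is expected, somewhat smaller than those two steps. The expected step is a 13-fold lower number from compound 3 to compound 4 (1.10 log units; beyond the scatter). Compound 4 is estimated at 300 nM, with an expected range from 90 nM to 1200 nM.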

Compound 4, half-maximal inhibitory concentration: 278 nM
Compound 4: the middle estimate sits 1.1-fold (0.03 log units) above what was measured; measured number inside the range.
By their numbers in this assay, from the lowest: compounds 1, 2 and 4 (each within the scatter of the next); then compound 3.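

In this assay, putting 2,6-dimethylphenyl in place of 4-(tert-butyl)phenyl gives a 14-fold lower number from compound 3 to compound 4 (1.14 log units; beyond the scatter), so a third group on this double-bonded chain carbon now stands well apart from compound 3. The other two new steps, a 1.6-fold higher number from compound 2 to compound 4 (0.20 log units; within the scatter) and a 1.8-fold higher number from compound 1 to compound 4 (0.26 log units; within the scatter), both lie within the scatter, so the two dimethylphenyl groups cannot be told apart here, and neither can 2,6-dimethylphenyl and 3-nitrophenyl. Among the four compounds, compounds 1, 2 and 4 therefore sit together, and compound 3, with its 4-(tert-butyl)phenyl group, is the only one that goes against them; nothing available explains why this group stands apart.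

The compounds shown leave open whether the tert-butyl group itself or its place on the ring sets compound 3 apart, since neither a 4-methylphenyl nor a 3-(tert-butyl)phenyl group is among them. They also leave open whether a plain phenyl ring, or a ring carrying an amine or a carboxylic acid, would stay at the level of compounds 1, 2 and 4.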